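Swapping a cyclopropyl for a thiophene on the pyridine core

This account rests on a few compounds, and the source may have more. Where it says the series, first, only, none or still open, it means among the compounds named here.

Measured so far:
- compound 1 `Cc1nc(C2CC2)cc2nn(-c3ccccc3)cc12`: 25900 nM
- compound 2 `CC(C)c1nc(-c2ccccc2)cc2nn(-c3ccccc3)cc12`: 36800 nM
- compound 3 `Cn1cc2cnc(-c3ccccc3)cc2n1`: > 100000 nM

The numbers come from a functional assay on K562 cells (Homo sapiens) for inhibition, read by fluorescence, with a stated time of 72 h; a higher number here means a weaker inhibitor of growth, a lower number a stronger inhibitor of growth. In this assay compound 1 gives 25900 nM, the lowest of the two numbers reported. Compound 2, which carries a phenyl and an isopropyl in place of the cyclopropyl and the methyl, gives 36800 nM, and that difference sits within the scatter, so no order between the two can be read. Compound 3 is reported only as a limit, > 100000 nM, because it reaches the limit of > 100000 nM in this assay, at which 1 of the 3 values shown sits, without a number.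

Compound 4 `Cc1nc(-c2ccsc2)cc2nn(-c3ccccc3)cc12` has not been measured. It differs from compound 1 in one place: thiophen-3-yl in place of cyclopropyl on an aromatic carbon. Within the data shown here, no pair among the measured compounds shows this single change, so its size is unknown. Compound 2 suggests that an aromatic ring at this position does not move the number out of the scatter, since compound 2 and compound 1 sit close together.

For compound 4 the expected value in this assay is 30000 nM, with a range from 10000 nM to 100000 nM. The step expected is a 1.2-fold higher number from compound 1 to compound 4 (0.06 log units; within the scatter), no more than the scatter in either direction.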

Compound 4, concentration for 50% growth inhibition: 10000 nM
For compound 4 the middle estimate is 3.0-fold (0.48 log units) above the measured one; the measured number falls inside the stated range.
By their numbers in this assay, from the lowest: compound 4; then compounds 1 and 2 (each within the scatter of the next). At a limit, above all of these: compound 3.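

In this assay the swap of cyclopropyl for thiophen-3-yl, on the aromatic carbon next to the ring nitrogen, gives a 2.6-fold lower number from compound 1 to compound 4 (0.41 log units; beyond the scatter) and is the only change shown that can be read on its own. Compounds 1 and 4 differ in this one place, so this pair gives the first direct sign that the group here can move the number by more than repeated measurements would. A five-membered aromatic ring with sulfur is accepted in place of a three-membered non-aromatic ring of carbon only, and the number goes down rather than up, although one pair cannot separate the part played by the aromatic ring, the sulfur or the larger group.

As far as these compounds go, whether an amine or a carboxylic acid on this same carbon would lower the number further, or raise it, remains open, as does whether the step would hold with another group in place of the methyl. None of the measurements shown gives a reason for the step.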